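From pyridin-4-yl to 4-bromophenyl: a cytotoxicity estimate

The compounds below may be only part of what the source reports. "The series", "measured", "known", "first", "only" and "open" are said of these compounds alone.

Measured in an ADME assay on H9c2 cells (Rattus norvegicus) for cytotoxicity, read by resazurin assay, with a stated time of 72 h; a lower number here means that less compound is tolerated, a higher number that more compound is tolerated:
- compound 1 `C/C(=N\N=c1\scc(-c2ccccc2)n1C)c1ccc(Cl)c(Cl)c1`: > 50000 nM (a limit of the assay, not a number)
- compound 2 `C/C(=N\Nc1nc(-c2ccncc2)cs1)c1ccc(Cl)c(Cl)c1`: 41900 nM
- compound 3 `C/C(=N\Nc1nc(-c2ccc(Cl)c(Cl)c2Cl)cs1)c1ccc(Cl)c(Cl)c1`: 17000 nM

Only two of these three results are actual numbers. Compound 1 reads > 50000 nM, which is a limit and not a number. Compound 2, at 41900 nM, has the higher of the two numbers. Its nearest neighbour is compound 3 at 17000 nM, and the gap between them lies beyond the usual scatter.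

Compound 4 `C/C(=N\Nc1nc(-c2ccc(Br)cc2)cs1)c1ccc(Cl)c(Cl)c1` has not yet been measured in this assay. Compared with compound 2, it has 4-bromophenyl in place of pyridin-4-yl on an aromatic carbon. Among the compounds with values here, no measured pair of compounds differs in just one place, so the expectation has little to rest on. The closest guide is compound 3, whose 17000 nM is lower than the number for compound 2. On that basis a lower number is expected, by a modest margin, and the estimated step is a 2.0-fold lower number from compound 2 to compound 4 (0.30 log units; within the scatter). The estimated value for compound 4 is 21000 nM, with an expected range of 9000 nM to 48000 nM.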

Compound 4, half-maximal cytotoxic concentration: > 50000 nM
Compound 4 gave a limit, no number; the forecaster's own chance of this, stated with the estimate: 20%; middle value at least 2.3-fold (0.37 log units) away from the limit.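

This is the first step among the compounds shown that changes one place only, the aromatic carbon next to the ring nitrogen of the five-membered aromatic ring, and in this assay it is an at least 1.1-fold higher number from compound 2 to compound 4 (0.07 log units; that floor lies within the scatter). It shows that replacing pyridin-4-yl, with its ring nitrogen, by 4-bromophenyl, a ring of carbon only that is one heavy atom larger, gives no lower number at this position, although the floor of the step does not establish a true rise. The real size of the step cannot be read, because the read-out ends at a limit: the limit of > 50000 nM in this assay, at which 2 of the 4 values shown sit.

The compounds shown leave open whether any single change at this aromatic carbon can lower the number in this assay, as every pair that differs in one place comes down to this one step, and that step ends at the limit. They also leave open how an amine or a carboxylic acid in place of the bromine of 4-bromophenyl would read in the same assay, and whether a longer chain at that spot would read any differently.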